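A few compounds are considered here, and "the series" means these few. Any claim that something is new, unique, unknown or untested is made for them only; others in the source may bear on it.

Compound 1 `N#Cc1cnc(NCc2cnccc2C(F)(F)F)cc1NC[C@H]1C[C@@H](O)C1`: 300 nM in an assay on isolated protein for inhibition of protein kinase C theta type (Homo sapiens), read by TR-FRET, with a stated time of 2 h; a lower number here means a stronger inhibitor, a higher number a weaker inhibitor.
Compound 2 `CO[C@H]1CC[C@H](Nc2cc(NCc3cnccc3C(F)(F)F)ncc2C#N)CC1`: 1100 nM.
Compound 3 `N#Cc1cnc(NCc2cnccc2C(F)(F)F)cc1NC[C@H]1CC[C@@H](O)CC1`: 58 nM.

Compound 3 gives the lowest number of the three measured compounds, with a 5.2-fold lower number from compound 1 to compound 3 (0.71 log units; beyond the scatter) and a 19-fold lower number from compound 2 to compound 3 (1.28 log units; beyond the scatter). Compound 4 `CO[C@H]1CC[C@@H](CNc2cc(NCc3cnccc3C(F)(F)F)ncc2C#N)CC1` keeps the core of compound 3 and alters one spot: methyl in place of hydrogen on an oxygen on a saturated carbon, which reads hydroxy to methoxy. Among the measured compounds shown here, no measured step isolates this single change. For the measured compounds named here, the only methoxy compound, compound 2, also differs from compound 3 in ring size and chain, so the steps of a 3.7-fold higher number from compound 1 to compound 2 (0.56 log units; beyond the scatter) and a 19-fold lower number from compound 2 to compound 3 (1.28 log units; beyond the scatter) only hint that a methoxy goes with a higher number. A modest rise is therefore expected for compound 4, a 2.6-fold higher number from compound 3 to compound 4 (0.41 log units; beyond the scatter). Compound 4 is estimated at 150 nM, within 50 nM to 500 nM.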

Compound 4, half-maximal inhibitory concentration: 70 nM
Beside the measured number, compound 4's estimate is 2.1-fold (0.33 log units) above it; low and high end bracket the measured number.
By their numbers in this assay, from the lowest: compounds 3 and 4 (each within the scatter of the next); then compound 1; then compound 2.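

In this assay, the methyl on this oxygen gives a 1.2-fold higher number from compound 3 to compound 4 (0.08 log units; within the scatter), so with the chain held fixed, hydroxy and methoxy cannot be told apart here. The large gap seen earlier therefore does not go with the methoxy: with methoxy on both sides, the (4-methoxycyclohexyl)methyl group in place of 4-methoxycyclohexyl gives a 16-fold lower number from compound 2 to compound 4 (1.20 log units; beyond the scatter). The 4-methoxycyclohexyl in place of 3-hydroxycyclobutyl on the chain carbon gives a 4.3-fold lower number from compound 1 to compound 4 (0.63 log units; beyond the scatter), close to the step seen with the hydroxy.

Nothing shown here explains these steps. From the compounds shown here alone, whether an ethoxy or an amine on this carbon would fit as well as the methoxy remains open.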